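The source may hold more compounds than are shown below. What is called first, only, known or untested is meant among the compounds shown, and "the series" means these compounds.

Compound 1, `NC(=O)c1c(NC(=O)c2ccccc2Cl)sc2c1CCN(Cc1ccccc1F)C2`: 21800 nM
Compound 2, `NC(=O)c1c(NC(=O)c2ccccc2Cl)sc2c1CCN(C(=S)Nc1cccc3ccccc13)C2`: 13400 nM

Both compounds were tested in a functional assay on HL-60 cells (Homo sapiens) for antiproliferative activity, with a stated time of 24 h; on this read-out lower numbers stand for stronger inhibition and higher numbers for weaker inhibition. Of the two numbers, compound 2 holds the lower one, yet the gap to compound 1 lies within the usual scatter of repeated measurements, so the two cannot be ranked against each other; all that can be said is that both inhibit the growth of these cells only at high concentrations.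

Compound 3, `NC(=O)c1c(NC(=O)c2ccccc2Cl)sc2c1CCN(C(=S)Nc1ccccc1I)C2`, has not been measured. It shares the whole core of compound 2, including the thiocarbonyl-bearing nitrogen, and differs in one place: 2-iodophenyl in place of naphthalen-1-yl on an amide-type nitrogen. Going by the values given here, no pair of measured compounds differs in a comparable way, so there is no measured step to lean on; what is known is only that the two measured compounds, which differ at this same nitrogen, sit within the scatter of each other.

On that basis the step from compound 2 to compound 3 is expected to be small, with no direction that can be stated beyond the scatter, a 1.1-fold higher number from compound 2 to compound 3 (0.05 log units; within the scatter). Compound 3 is therefore estimated at 15000 nM, with a likely range from 5000 nM to 45000 nM.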

Compound 3, half-maximal inhibitory concentration: 4430 nM
For compound 3 the middle estimate is 3.4-fold (0.53 log units) above the measured one, and the stated range ends above it.
By their numbers in this assay, from the lowest: compound 3; then compounds 2 and 1 (each within the scatter of the next).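

In this assay, going by these compounds alone, the group on the amide-type nitrogen now proves able to shift the number: 2-iodophenyl in place of naphthalen-1-yl gives a 3.0-fold lower number from compound 2 to compound 3 (0.48 log units; beyond the scatter), the first step at this position that can be told apart from scatter. Replacing the whole substituent on the amine nitrogen in the ring gives a 4.9-fold lower number from compound 1 to compound 3 (0.69 log units; beyond the scatter), so this single compound stands clear of both earlier ones, which could not be ranked against each other, although both steps remain modest in size. Nothing measured here explains why the 2-iodophenyl compound gives the lower number.

The change swaps two aromatic rings for one and also brings in an iodine, so the compounds shown cannot separate these two parts of it. Plain phenyl on the same nitrogen would isolate the effect of the iodine, while 2-bromophenyl or 2-chlorophenyl would show whether another halogen gives a similar number, and 3-iodophenyl or 4-iodophenyl whether the place of the iodine on the ring matters.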